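Swapping methoxy for bromo at the assay limit

The source may report more compounds than this note shows. Statements on the series, on what has been measured and on what is new or still open speak of the compounds shown alone.

Measured so far in a toxicity assay on THP-1 cells (Homo sapiens) for inhibition; on this read-out higher numbers stand for lower toxicity in this test and lower numbers for higher toxicity in this test
compound 1 `COc1ccc(-c2cnc(NC(=O)c3ccc(C)cc3)n2C)cc1` gives > 100000 nM as a limit
compound 2 `COc1ccc(-c2cnc(NC(=O)c3cccc(OC)c3)n2C)cc1` gives > 100000 nM as a limit

Compound 2 therefore stands at a limit of the assay, with no exact number. Compound 3 `COc1ccc(-c2cnc(NC(=O)c3cccc(Br)c3)n2C)cc1` has not yet been measured. It differs from compound 2 in one place, and bromo in place of methoxy on an aromatic carbon gives the count of that change. Within the data shown here, the only measured step is a step that the two limits leave unreadable from compound 1 to compound 2 and it offers no size to carry over. All that the data show is the limit of > 100000 nM in this assay, at which 2 of the 2 values shown sit, and nothing more. Compound 2 at > 100000 nM is a limit, so no step beyond the scatter is expected in this assay and no direction can be foreseen. The estimate is a number no higher from compound 2 to compound 3 (the limit leaves the size open) for the expected change. The expected value for compound 3 is 100000 nM with an estimated range from 40000 nM to 200000 nM as the likely span.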

Compound 3, half-maximal cytotoxic concentration: > 100000 nM
Compound 3 was reported as a limit; the forecaster's own chance of this, stated with the estimate: 85%; the middle value sits exactly at the limit.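

Among these compounds, compound 1, compound 2 and compound 3 all sit at the same limit in this assay, so no step among them can be read. The compounds shown leave open whether swapping methoxy for bromo changes toxicity at all, as the data show only this: the limit of > 100000 nM in this assay, at which 3 of the 3 values shown sit.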